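Swapping the aryl group on a shared imidazopyrazine core

A few compounds are considered here, and "the series" means these few. Any claim that something is new, unique, unknown or untested is made for them only; others in the source may bear on it.

Among the measured compounds shown here, compound 2 `Clc1ccc(-c2cn3ccnc3c(-c3ccc4ncn(C5CCCCC5)c4c3)n2)cc1` gives 3.78% in a functional assay on OVCAR-8 cells (Homo sapiens) for inhibition, read by sulforhodamine B assay, with a stated time of 48 h, tested at 10 uM (on this read-out lower numbers stand for less inhibition and higher numbers for more inhibition at the one concentration tested (going by the name of the read-out)), and stands as the lower of the two numbers so far; the only other measured member, compound 1 `O=Cc1ccc(-c2cn3ccnc3c(-c3ccc4ncn(C5CCCCC5)c4c3)n2)cc1`, gives 44% in this assay. For the measured compounds named here, the one measured step, a number 40.2 percentage points lower from compound 1 to compound 2 (beyond the scatter), shows that changing the substituent on this phenyl ring can move the read-out a long way. Compound 3 `COc1ccccc1-c1cn2ccnc2c(-c2ccc3ncn(C4CCCCC4)c3c2)n1` differs from compound 2 by 2-methoxyphenyl in place of 4-chlorophenyl on an aromatic carbon. Going by the values given here, no measured step involves a 2-methoxyphenyl group, so the direction of this change cannot be read from the data; what the pair of values does show is that the outcome spans a wide range. Compound 3 is therefore expected to fall somewhere between the two measured numbers, with an estimated step of a number 14.2 percentage points higher from compound 2 to compound 3 (beyond the scatter) and an estimated value of 18%, within a range from 0% to 50%.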

Compound 3, a percentage reported as inhibition, at one concentration (the size of the read-out at that concentration, not a potency): 8.78%
The estimate for compound 3 lay 9.2 percentage points above the measured number; low and high end bracket the measured number.
By their numbers in this assay, from the lowest: compounds 2 and 3 (each within the scatter of the next); then compound 1.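

Going from 4-chlorophenyl to 2-methoxyphenyl at this aromatic carbon gives a number 5 percentage points higher from compound 2 to compound 3 (within the scatter) in this assay, so the read-out does not separate these two groups, although they differ in ring substitution and the incoming group carries a hydrogen-bond acceptor. The comparison with the 4-formylphenyl group gives a number 35.2 percentage points lower from compound 1 to compound 3 (beyond the scatter) and, together with the earlier step, sets compound 1 apart from both other members of this small set. No measurement at hand accounts for this difference. As far as these compounds go, whether a phenyl ring carrying a carboxylic acid or an amine in place of the formyl group would keep the read-out of compound 1 remains open. So does whether a 4-methoxyphenyl group would behave like the 2-methoxyphenyl group of compound 3.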